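The compounds below may be only part of what the source reports. "The series", "measured", "known", "first", "only" and "open" are said of these compounds alone.

Measured compounds:
- compound 1, `COc1cc(C)cc(-c2c(-c3ccnc(-c4ccc(N(C)C)cc4)c3)cnn2CC#N)c1` — 65%
- compound 2, `COc1cc(C)cc(-c2nn(CC#N)cc2-c2ccnc(-c3ccc(N(C)C)cc3)c2)c1` — 98%
- compound 3, `COc1cc(C)cc(-c2nn(CC#N)cc2-c2ccc(-c3cccc(C(C)=O)c3)nc2)c1` — 83%

In a functional assay on SNB-75 cells (Homo sapiens) for cytotoxicity, read by sulforhodamine B assay, with a stated time of 48 h, tested at 0.01 uM (on this read-out higher numbers stand for a weaker effect at the one concentration tested and lower numbers for a stronger effect), compound 2 gives 98%, the highest of the three numbers, so the weakest effect at the one concentration tested. Its nearest neighbour on the numbers is compound 3, whose 83% lies beyond the scatter; compound 1, with 65%, lies further still, also beyond the scatter. Within the data shown here, no step between compounds differing in a single place is available, so nothing here separates the effect of any one group from the rest of the structure.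

Compound 4, `Cc1cc(O)cc(-c2nn(CC#N)cc2-c2ccnc(-c3ccc(N(C)C)cc3)c2)c1`, is not yet measured. It is derived from compound 2 by one change: hydrogen in place of methyl on an oxygen on an aromatic ring.

Among the measured compounds shown here, with no single-place step to lean on, and compound 2 already at a number close to no effect, the expectation for compound 4 in this assay is a small shift at most, if any, towards a slightly stronger effect, most likely within the scatter. The estimated step from compound 2 to compound 4 is a number 6 percentage points lower from compound 2 to compound 4 (within the scatter). Compound 4 is therefore expected to give about 92%, within a range from 78% to 104%.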

Compound 4, a percentage reported as activity, at one concentration (the size of the read-out at that concentration, not a potency): 75%
Estimate against measurement, compound 4: 17 percentage points above, outside the stated range (below it).
By their numbers in this assay, from the lowest: compounds 1, 4 and 3 (each within the scatter of the next, the first and the last beyond it); then compound 2.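

In this assay, hydrogen in place of methyl on an oxygen on an aromatic ring, methoxy to hydroxy, gives a number 23 percentage points lower from compound 2 to compound 4 (beyond the scatter). Among these compounds, this is the only single-place step, and it shows that this position affects the read-out: the hydroxy form has the stronger effect at the one concentration tested. No measurement bears on the reason for this step.

The compounds shown leave open whether the gain depends on the free hydroxy itself, as an amine or an ethoxy group in its place could show. Among the compounds shown here, they also leave open whether methoxy to hydroxy gives a step of similar size with the other arrangements of the shared core, and a single concentration gives no potency for either compound.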